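Aryl change from compound 2 to compound 3

A few compounds are considered here, and "the series" means these few. Any claim that something is new, unique, unknown or untested is made for them only; others in the source may bear on it.

Measured so far in an ADME assay on Caco-2 cells (Homo sapiens) for permeability, read by LC-MS, in the apical to basolateral direction, with a stated time of 2 h, tested at 2 uM; on this read-out higher numbers stand for higher permeability and lower numbers for lower permeability:
Compound 1 `CCOc1ccccc1-c1ccc(-c2nc3cnccc3c(C[C@H](C)C(=O)O)c2C#N)cc1`: 43 nm/s
Compound 2 `CCOc1ccccc1-c1ccc(-c2nc3cnccc3c(N[C@H](CC)C(N)=O)c2C#N)cc1`: 151 nm/s

Of these two, compound 2 has the higher number, at 151 nm/s. Within the data shown here, the gap is the single measured step, a 3.5-fold higher number from compound 1 to compound 2 (0.55 log units; beyond the scatter), which is modest but beyond the scatter. That step replaces 2-carboxypropyl with (1-carbamoylpropyl)amino, and both compounds carry 2-ethoxyphenyl.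

The next change leaves that side of the shared core alone. Compound 3 `CC[C@@H](Nc1c(C#N)c(-c2ccc(-c3cccc(OC)c3)cc2)nc2cnccc12)C(N)=O` differs from compound 2 in one place: 3-methoxyphenyl in place of 2-ethoxyphenyl on an aromatic carbon. The new group, 3-methoxyphenyl, sits on an aromatic carbon para to a large group.

Among the measured compounds shown here, no measured pair varies this group, so the one measured step gives no size or direction for this change. Working from compound 2 at 151 nm/s, no shift beyond the scatter is expected in this assay. The estimated step is a 1.1-fold lower number from compound 2 to compound 3 (0.03 log units; within the scatter). For compound 3 the expected value is 140 nm/s, with an estimated range of 60 nm/s to 320 nm/s.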

Compound 3, apparent permeability: 104 nm/s
Compound 3: middle estimate off by 1.3-fold (0.13 log units), on the high side, within the range that was stated.
By their numbers in this assay, from the lowest: compound 1; then compounds 3 and 2 (each within the scatter of the next).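

In this assay, placing 3-methoxyphenyl on the aromatic carbon para to a large group in place of 2-ethoxyphenyl gives a 1.5-fold lower number from compound 2 to compound 3 (0.16 log units; within the scatter), so this first variation of the group leaves the two compounds unseparated on this read-out. The change alters two features at once, the ether chain and where it sits on the outer ring, and this single pair cannot assign any part of the small difference to either feature; the hydrogen-bond donor and acceptor counts of the two groups are the same, while the heavy-atom count goes from 9 to 8. No supporting data on the cause of this result are available here.

On these data alone, it remains open whether a group of a different kind at this place, such as an aminomethyl, a carboxylic acid or a longer alkoxy chain, would give a step beyond the scatter. Also open, as far as these compounds go, is whether the step seen from 2-carboxypropyl to (1-carbamoylpropyl)amino with 2-ethoxyphenyl in place would carry over to compounds bearing 3-methoxyphenyl.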